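The compounds below may be only part of what the source reports. "The series", "measured", "known", "first", "only" and "open" are said of these compounds alone.

Working notes on the series in a physicochemical assay for metabolic stability, read by HPLC, in phosphate buffer, with a stated time of 12 h, at pH 7.2; a lower number here means that the compound disappears faster, a higher number that the compound lasts longer. Compound 1 `O=C(O)[C@H](CO)NC(=O)[C@H]1C[C@H](O)CN1` sits at the limit of this assay: compound 1 gives > 12 h, a limit rather than a number. Compound 2 `O=C(O)[C@@H](CO)NC(=O)[C@H]1C[C@@H](O)CN1` likewise: in this assay compound 2 gives > 12 h, again a limit. Compound 3 `O=C(O)[C@@H](CO)NC(=O)[C@H]1C[C@H](O)CN1` behaves the same way: compound 3 gives > 12 h, also a limit. Within the data shown here, compound 2 therefore stands where every measured value of the set stands, at the limit (the limit of > 12 h in this assay, at which 3 of the 3 values shown sit), and no member of the set stands apart from it. The steps among the three, a step that the two limits leave unreadable from compound 1 to compound 2, a step that the two limits leave unreadable from compound 1 to compound 3 and a step that the two limits leave unreadable from compound 2 to compound 3, are unreadable in size; each is a change of configuration only (the fact that compounds 1 and 2 differ only in the configuration as drawn, (the fact that compounds 1 and 3 differ only in the configuration as drawn), (the fact that compounds 2 and 3 differ only in the configuration as drawn)).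

Compound 4 `O=C(O)[C@H](CO)NC(=O)[C@H]1C[C@@H](O)CN1` is the remaining stereoisomer of the shared core. It differs from compound 2 as follows: the two compounds have the same atoms and bonds and differ only in configuration as drawn: 1 of 3 stereo elements differ; a stereocentre at a saturated chain carbon is drawn R in compound 2 and S in compound 4. Among the measured compounds shown here, the steps that bear on it are the configuration-only steps above, none of which gave a readable size because every value sits at the limit (the limit of > 12 h in this assay, at which 3 of the 3 values shown sit). No step beyond the scatter is expected in this assay for compound 4, and a further limit is the likelier outcome. The resulting step is expected to be a step that the limit leaves unreadable from compound 2 to compound 4. For compound 4 the estimate in this assay is 20 h, with a range from 12 h to 40 h.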

Compound 4, half-life: > 12 h
Compound 4: only a limit was reported (the forecaster's own chance of this, stated with the estimate: 85%); the middle value does not contradict the limit.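

In this assay compound 4 gives > 12 h, a limit and not a number. No step among compounds 1, 2, 3 and 4 can be read, since all four sit at that limit: the limit of > 12 h in this assay, at which 4 of the 4 values shown sit.

The compounds shown leave open whether the configuration at the saturated chain carbon or the saturated ring carbon changes the half-life at all.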